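The source may hold more compounds than are shown below. What is called first, only, known or untested is meant among the compounds shown, and "the series" means these compounds.

In a functional assay on HL-60 cells (Homo sapiens) for antiproliferative activity, read by MTT assay, with a stated time of 48 h (on this read-out lower numbers stand for stronger inhibition and higher numbers for weaker inhibition), compound 2 `CC(C)=CCC[C@]1(C)/C=C/[C@@H](OC(=O)C=C(C)C)[C@](C)(O)/C=C/C(=O)/C(CN(C)C)=C\C1` gives 140 nM and compound 1 `CC(C)=CCC[C@]1(C)/C=C/[C@@H](OC(=O)C=C(C)C)[C@](C)(O)/C=C/C(=O)/C(CCl)=C\C1` gives 160 nM, so the two stand within the scatter of each other. Compound 3 `CCN(CC)C/C1=C/C[C@](C)(CCC=C(C)C)/C=C/[C@@H](OC(=O)C=C(C)C)[C@](C)(O)/C=C/C1=O` differs from compound 2 by diethylamino in place of dimethylamino on a saturated chain carbon bound to a double-bonded ring carbon. Within the data shown here, the only measured step that bears on this, a 1.1-fold lower number from compound 1 to compound 2 (0.06 log units; within the scatter), exchanged chloro for dimethylamino at that carbon and stayed within the scatter. No step beyond the scatter is therefore expected in this assay, and the expected step is a 1.1-fold higher number from compound 2 to compound 3 (0.03 log units; within the scatter). Compound 3 is estimated at 150 nM, with an expected range of 60 nM to 380 nM.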

Compound 3, half-maximal inhibitory concentration: 140 nM
Compound 3: the middle estimate sits 1.1-fold (0.03 log units) above what was measured, within the range that was stated.
By their numbers in this assay, from the lowest: compounds 2, 3 and 1 (each within the scatter of the next).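

In this assay diethylamino in place of dimethylamino on a saturated chain carbon bound to a double-bonded ring carbon gave no change at the digits printed from compound 2 to compound 3 (within the scatter) and diethylamino in place of chloro gave a 1.1-fold lower number from compound 1 to compound 3 (0.06 log units; within the scatter). Beyond the earlier single exchange, this shows that a second amine at this carbon also leaves the number within the scatter of both earlier compounds. No data at hand explain this result. From the compounds shown here alone, whether a carboxylic acid or a morpholine group at this carbon would also stay within the scatter remains open.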